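Trifluoromethyl for dimethylamino on a pyridine chalcone

The source may report more compounds than this note shows. Statements on the series, on what has been measured and on what is new or still open speak of the compounds shown alone.

Working notes on a small set of enone compounds measured in a functional assay with Rattus norvegicus as the target; a lower number here means a stronger inhibitor, a higher number a weaker inhibitor. Compound 2 `CN(C)c1cccc(C(=O)/C=C/c2ccncc2)c1` gives 19000 nM in this assay. Compound 3 `COc1cc(C(=O)/C=C/c2ccccn2)cc(OC)c1OC` gives 18000 nM in this assay, and the two numbers sit within the usual scatter of each other, so no order between them can be read. Compound 1 `COc1cc(C(=O)/C(C)=C/c2ccncc2)cc(OC)c1OC` returns only a limit in this assay, > 100000 nM; (the limit of > 100000 nM in this assay, at which 1 of the 3 values shown sits). Among the two real numbers, compound 2 stands highest, with compound 3 nearest to it.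

Compound 4 `O=C(/C=C/c1ccncc1)c1cccc(C(F)(F)F)c1` differs from compound 2 in one place: trifluoromethyl in place of dimethylamino on an aromatic carbon. Within the data shown here, no measured pair in the set separates this kind of change, so nothing here indicates how large a step to expect; the step from compound 2 to compound 4 is estimated at a 1.1-fold higher number from compound 2 to compound 4 (0.02 log units; within the scatter), that is, none beyond the scatter, with wide uncertainty in either direction. Compound 4 is therefore expected to give about 20000 nM in this assay, within a range from 5000 nM to 80000 nM.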

Compound 4, half-maximal inhibitory concentration: 41000 nM
The estimate for compound 4 lay 2.1-fold (0.31 log units) below the measured number, within the range that was stated.
By their numbers in this assay, from the lowest: compounds 3 and 2 (each within the scatter of the next); then compound 4. At a limit, above all of these: compound 1.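

In this assay, among these compounds, trifluoromethyl in place of dimethylamino on an aromatic carbon, meta to a large group, gives a 2.2-fold higher number from compound 2 to compound 4 (0.33 log units; beyond the scatter), the first step in this set that can be read. This place on the ring therefore responds to the group it carries, though only modestly, and the change also takes away the hydrogen-bond acceptor counted for dimethylamino. Nothing measured here bears on the reason for this step.

On these data alone, a single pair cannot show whether the step follows from that acceptor or from something else about the two groups, and what a nitrile, a primary amine or a carboxylic acid would give at this place remains open. As far as these compounds go, it is also open whether the same change would give a step of similar size on the core of compound 3.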